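The source may report more compounds than this note shows. Statements on the series, on what has been measured and on what is new or still open speak of the compounds shown alone.

Measured so far:
- compound 1, `C=CCc1cc(O)c(O)c(CN2CCC(CO)CC2)c1`, 43.3%
- compound 2, `C=CCc1cc(O)c(O)c(CN2CCC(CCO)CC2)c1`, 52.1%

For the measured compounds named here, in a functional assay on HL-60 cells (Homo sapiens) for inhibition, read by MTT assay, with a stated time of 72 h, tested at 50 uM (a lower number here means less inhibition of growth, a higher number more inhibition of growth at the concentration tested), compound 2 gives the higher of the two numbers known, but its nearest neighbour, compound 1, lies within the usual scatter of it, so the two are not told apart. Going by the values given here, the only measured step, a number 8.8 percentage points higher from compound 1 to compound 2 (within the scatter), changes the same place on the saturated chain as the step considered here, yet by a different group, and it stays within the scatter.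

Compound 3, `C=CCc1cc(O)c(O)c(CN2CCC(Cc3ccccc3)CC2)c1`, has not been measured. It differs from compound 2 in one place: phenyl in place of hydroxymethyl on a saturated chain carbon bound to a saturated ring carbon. The measured step bears on it only in that it shows this place has so far tolerated a change without a step beyond the scatter; it says nothing about a phenyl entering in place of a hydroxymethyl, so no direction can be read from the data. For compound 3 a step of a number 2.1 percentage points lower from compound 2 to compound 3 (within the scatter) is expected, which is to say none beyond the scatter, with wide uncertainty. Compound 3 is therefore estimated at 50%, in a range from 28% to 75%.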

Compound 3, percent growth inhibition at one concentration: 94.4%
The estimate for compound 3 lay 44.4 percentage points below the measured number; measured number outside the range, above it.
By their numbers in this assay, from the lowest: compounds 1 and 2 (each within the scatter of the next); then compound 3.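

In this assay, for the compounds shown here, the place on a saturated chain carbon bound to a saturated ring carbon proves sensitive to what sits there: phenyl in place of hydroxymethyl gives a number 42.3 percentage points higher from compound 2 to compound 3 (beyond the scatter), whereas the one earlier step stayed within the scatter. The comparison with the other alcohol-bearing compound, with phenyl in place of hydroxy, points the same way, giving a number 51.1 percentage points higher from compound 1 to compound 3 (beyond the scatter), so swapping either alcohol side chain for this aromatic ring goes with much stronger growth inhibition at the concentration tested. Nothing available here explains why this step is so large.

This single change removes the hydroxy group, with its hydrogen-bond donor and acceptor, and brings in a six-membered aromatic ring of carbon only, so the compounds shown cannot tell whether the higher number goes with the loss of the hydroxy group, the arrival of the ring, or both together. On these data alone, a cyclohexyl group, which has a ring but is not aromatic, a plain propyl chain, which has neither ring nor hydroxy group, or an amine at this place could help separate these possibilities, and how each would read remains open.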